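Lengthening the Amine Chain from Compound 3 to Compound 4

The compounds below may be only part of what the source reports. "The series", "measured", "known", "first", "only" and "open" are said of these compounds alone.

In an ADME assay on HepG2 cells (Homo sapiens) for cytotoxicity, read by luminescence, with a stated time of 72 h (on this read-out lower numbers stand for an effect already at smaller amounts and higher numbers for an effect only at larger amounts of compound), compound 1 `CCOC(=O)c1c(-c2cccc(Oc3ccccc3)c2)[nH]c2cc(OC)ccc2c1=O` gives > 21500 nM, a limit and not a number. Compound 2 `CCOC(=O)c1c(-c2cccc(Cl)c2)[nH]c2cc(OC)c(F)cc2c1=O` likewise gives only a limit, > 21500 nM. Compound 3 `COc1ccc2c(=O)c(C(=O)OCCCN(C)C)c(-c3cccc(Oc4ccccc4)c3)[nH]c2c1` also stands at a limit, > 21500 nM, which places it with the others at the limit of > 21500 nM in this assay, at which 3 of the 3 values shown sit.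

Compound 4 `COc1ccc2c(=O)c(C(=O)OCCCCCCN(C)C)c(-c3cccc(Oc4ccccc4)c3)[nH]c2c1` carries 3-(dimethylamino)propyl in place of dimethylamino on a saturated chain carbon, three bonds along the chain from an oxygen next to a carbonyl group. Within the data shown here, the one measured step that bears on this change is a step that the two limits leave unreadable from compound 1 to compound 3, so it offers no size to carry over. A modest move toward lower numbers is therefore expected in this assay, and another limit remains quite possible. The expected change is an at least 1.4-fold lower number from compound 3 to compound 4 (0.15 log units; that floor lies within the scatter). Compound 4 is estimated at 15000 nM, within a range of 5000 nM to 21500 nM.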

Compound 4, half-maximal effective concentration: > 21500 nM
Compound 4: a limit, no number; the forecaster's own chance of this, stated with the estimate: 55%; middle value at least 1.4-fold (0.15 log units) away from the limit.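

Compound 4 also stands at a limit, and the steps to it from compound 1 and compound 3 cannot be read: the limit of > 21500 nM in this assay, at which 4 of the 4 values shown sit.

In this assay the compounds shown leave open at what concentration any of them would show an effect.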